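The source may hold more compounds than are shown below. What is called first, only, known or untested is meant among the compounds shown, and "the series" means these compounds.

Measured so far in an ADME assay on HEK293 cells for agonist activity at Toll-like receptor 8 (Homo sapiens), read by a luciferase reporter, with a stated time of 6 h; on this read-out higher numbers stand for an effect only at larger amounts of compound and lower numbers for an effect already at smaller amounts:
compound 1 `CCNc1nc(N)nc2ccccc12`: 0.77 uM
compound 2 `CCCNc1nc(N)nc2ccccc12`: 0.93 uM
compound 3 `CCCCCNc1nc(N)nc2ccccc12`: 0.1 uM

Compound 1 stands second highest of these three numbers; compound 2 lies within the scatter of it, while compound 3 sits clearly lower. Compound 4 `CC(C)CCNc1nc(N)nc2ccccc12` differs from compound 1 by isopropyl in place of hydrogen on a saturated chain carbon, two bonds along the chain from a nitrogen on an aromatic ring.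

For the measured compounds named here, two measured steps bear on this change. The closest is a 7.7-fold lower number from compound 1 to compound 3 (0.89 log units; beyond the scatter), the same place and the same kind of chain growth, only with propyl rather than isopropyl entering. The step of a 9.3-fold lower number from compound 2 to compound 3 (0.97 log units; beyond the scatter) points the same way, whereas a 1.2-fold higher number from compound 1 to compound 2 (0.08 log units; within the scatter) shows that a single added methyl leaves the number where it was. A lowering of about the size seen for compound 3 is therefore expected, a 5.1-fold lower number from compound 1 to compound 4 (0.71 log units; beyond the scatter). The value expected for compound 4 is 0.15 uM, with a range from 0.05 uM to 0.45 uM.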

Compound 4, minimum effective concentration: 2.11 uM
Compound 4: the middle estimate sits 14-fold (1.15 log units) below what was measured; measured number above the stated range.
By their numbers in this assay, from the lowest: compound 3; then compounds 1 and 2 (each within the scatter of the next); then compound 4.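

In this assay, the direction at this place depends on which group enters, not merely on growth of the chain: a 21-fold higher number from compound 3 to compound 4 (1.32 log units; beyond the scatter) separates isopropyl from propyl, a large step. Isopropyl in place of hydrogen gives a 2.7-fold higher number from compound 1 to compound 4 (0.44 log units; beyond the scatter) and isopropyl in place of methyl gives a 2.3-fold higher number from compound 2 to compound 4 (0.36 log units; beyond the scatter) so the lowering seen with propyl does not carry over to this group. Nothing measured here accounts for the difference between these two groups.

Still open, as far as these compounds go, is how a longer chain such as hexyl would read at this place. An amine or a carboxylic acid on the chain also remains an open question.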